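The source may report more compounds than this note shows. Statements on the series, on what has been measured and on what is new or still open speak of the compounds shown alone.

Series notes, antiproliferative read-out.

The three measured compounds share one core and differ in the aryl group on the triazole nitrogen. In a functional assay on HepG2 cells (Homo sapiens) for antiproliferative activity, read by MTT assay, with a stated time of 48 h (on this read-out higher numbers stand for weaker inhibition and lower numbers for stronger inhibition), compound 1 `N#CC1=C(N)Oc2c(c3nc4ccccc4nc3c3ccccc23)C12C(=O)N(Cc1cnnn1-c1ccc(N)cc1)c1ccccc12` gives only a limit of the assay, > 50000 nM. Compound 2 `Cc1ccc(Cl)cc1-n1nncc1CN1C(=O)C2(C(C#N)=C(N)Oc3c2c2nc4ccccc4nc2c2ccccc32)c2ccccc21` likewise gives only a limit in this assay, > 50000 nM. Going by the values given here, the one change between them, a step that the two limits leave unreadable from compound 1 to compound 2, is therefore not readable in size. Among the compounds with values here, compound 3 `CCc1ccccc1-n1nncc1CN1C(=O)C2(C(C#N)=C(N)Oc3c(N)cc4nc5ccccc5nc4c32)c2ccccc21` is the only compound with a number: in this assay compound 3 gives 17900 nM. Compounds 1 and 2 sit at a limit of the assay (the limit of > 50000 nM in this assay, at which 2 of the 3 values shown sit).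

Compound 4 `N#CC1=C(N)Oc2c(N)cc3nc4ccccc4nc3c2C12C(=O)N(Cc1cnnn1-c1c(F)cccc1F)c1ccccc12` is the next member. Its change from compound 3 is 2,6-difluorophenyl in place of 2-ethylphenyl on an aromatic nitrogen. Within the data shown here, no measured step concerns this change; the single step recorded is unreadable, so nothing supports a directional expectation. The step of a 1.1-fold higher number from compound 3 to compound 4 (0.05 log units; within the scatter) is therefore estimated as none beyond the scatter, with wide uncertainty. For compound 4 the expected value in this assay is 20000 nM, within a range of 6000 nM to 60000 nM.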

Compound 4, half-maximal inhibitory concentration: > 50000 nM
Compound 4: only a limit was reported; the forecaster's own chance of this, stated with the estimate: 40%; middle value at least 2.5-fold (0.39 log units) away from the limit.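

The size of a change at this position can now be read, which the two limits of the earlier step did not allow: in this assay the series shows an at least 2.7-fold higher number from compound 3 to compound 4 (0.44 log units; beyond the scatter). The 2-ethylphenyl and 2,6-difluorophenyl groups have the same counts of heavy atoms, hydrogen-bond donors and hydrogen-bond acceptors, so these counts alone do not settle the read-out at this position. Compound 4 gives only a limit of the assay, which leaves compound 3 as the sole compound with a number: the limit of > 50000 nM in this assay, at which 3 of the 4 values shown sit.

The step therefore has a lower bound on its size and no upper bound. The compounds shown leave open whether a longer chain in place of the ethyl group, or a methoxy group on the phenyl ring, would hold or improve on compound 3 at 17900 nM.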